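Branched ether chains and affinity in a shared core

The source may hold more compounds than are shown below. What is called first, only, known or untested is meant among the compounds shown, and "the series" means these compounds.

Compound 1 `CCc1sc(CCc2cc(OC)cc(NCc3cc(Cl)cc(NC(=O)OC(C)C)c3)n2)nc1C`: in an assay on cells for binding affinity to Neuropeptide Y receptor type 1 (Homo sapiens) (a lower number here means a stronger inhibitor, a higher number a weaker inhibitor), compound 1 gives 234 nM
Compound 2 `CCCCCOc1cc(CCc2nc(C)c(CC)s2)nc(NCc2cc(Cl)cc(NC(=O)OC(C)C)c2)c1`: compound 2 gives 35 nM
Compound 3 `CCc1sc(CCc2cc(OC(C)C)cc(NCc3cc(Cl)cc(NC(=O)OC(C)C)c3)n2)nc1C`: compound 3 gives 12 nM

All three share one core and differ only in the group sitting on an oxygen on an aromatic ring. Compound 3 holds the lowest number of the three in this assay: it is separated from compound 2 by a 2.9-fold lower number from compound 2 to compound 3 (0.46 log units; beyond the scatter) and from compound 1 by a 20-fold lower number from compound 1 to compound 3 (1.29 log units; beyond the scatter), both beyond the scatter, so compound 3 is the strongest inhibitor shown.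

Compound 4 `CCc1sc(CCc2cc(OCC(C)(C)C)cc(NCc3cc(Cl)cc(NC(=O)OC(C)C)c3)n2)nc1C` takes the next step: neopentyl in place of isopropyl on an oxygen on an aromatic ring. Among the compounds with values here, two measured steps bear on it. Enlarging the group from methyl gave a 6.7-fold lower number from compound 1 to compound 2 (0.83 log units; beyond the scatter) and a 20-fold lower number from compound 1 to compound 3 (1.29 log units; beyond the scatter), while moving from a straight chain to a branched one of fewer carbons gave a 2.9-fold lower number from compound 2 to compound 3 (0.46 log units; beyond the scatter). Neopentyl is larger than isopropyl yet branched, so the two trends pull against each other, and no step beyond the scatter is expected in this assay. The estimated step is a 1.3-fold higher number from compound 3 to compound 4 (0.10 log units; within the scatter). Compound 4 is therefore expected to give about 15 nM, within a range from 5 nM to 50 nM.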

Compound 4, half-maximal inhibitory concentration: 55 nM
Estimate against measurement, compound 4: 3.7-fold (0.56 log units) below; measured number outside the range, above it.
By their numbers in this assay, from the lowest: compound 3; then compounds 2 and 4 (each within the scatter of the next); then compound 1.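

At this place, on an oxygen on an aromatic ring, a bigger branched group does not extend the gain seen with isopropyl: in this assay, exchanging isopropoxy for neopentyloxy reverses part of it (a 4.6-fold higher number from compound 3 to compound 4 (0.66 log units; beyond the scatter)), so branching alone does not secure a low number. Neopentyl still keeps an advantage over the methyl of the shared series (a 4.3-fold lower number from compound 1 to compound 4 (0.63 log units; beyond the scatter)), yet it cannot be told apart from the straight pentyl chain (a 1.6-fold higher number from compound 2 to compound 4 (0.20 log units; within the scatter)), so among these four compounds the number neither keeps falling with larger groups nor separates branched chains from straight ones, with compound 3 alone standing clear of the other three. Nothing measured here explains why neopentyl fares worse than isopropyl on this oxygen.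

The compounds shown leave open how narrow the favoured size is, since an ethyl, a cyclopropyl or a cyclobutyl group on the same oxygen would fall among the groups already compared. They also leave open whether this place accepts a chain ending in an amine or a hydroxyl group, as every group here is built of carbon alone.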